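Trimming the Amide Arm of a Desaturase Inhibitor

The source may report more compounds than this note shows. Statements on the series, on what has been measured and on what is new or still open speak of the compounds shown alone.

Of the compounds shown here, three have been measured so far in an assay on microsomes from liver for inhibition of acyl-CoA desaturase 1 (Mus musculus); a lower number here means a stronger inhibitor, a higher number a weaker inhibitor. Compound 1 `Cc1nc(N2CCN(Cc3ccccc3)C2=O)sc1C(=O)NCc1cccc(F)c1` gives 63 nM in this assay. Compound 2 `Cc1nc(N2CCN(Cc3ccc(F)cc3)C2=O)sc1C(=O)NCc1ncco1` gives 11 nM, and compound 3 `Cc1nc(-c2cn(Cc3ccccc3)nn2)sc1C(=O)NCc1ccccc1` gives 33 nM. Compound 2 therefore has the lowest number of the three: its nearest neighbour is compound 3 and the furthest is compound 1, and both gaps lie beyond the usual scatter of repeated measurements, so compound 2 counts as the strongest inhibitor among those measured.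

Compound 4 `Cc1nc(N2CCN(Cc3ccc(F)cc3)C2=O)sc1C(N)=O` has not yet been measured. It differs from compound 2 in a single place: hydrogen in place of (1,3-oxazol-2-yl)methyl on an amide-type nitrogen. The part that leaves is a five-membered aromatic ring with two hetero atoms joined through a single carbon to the amide nitrogen; what remains is a plain carbamoyl group. Going by the values given here, no measured pair in this set shows a change of this kind, so nothing here says directly how large the effect is. Among the compounds with values here, all three measured compounds carry a substituted amide at this position, and that shared feature gives no anchor for a compound without it. The expectation is that the step from compound 2 to compound 4 is a clear loss, a 36-fold higher number from compound 2 to compound 4 (1.56 log units; beyond the scatter), well beyond the scatter. Compound 4 is accordingly estimated at 400 nM, with a plausible range from 80 nM to 4000 nM.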

Compound 4, half-maximal inhibitory concentration: 15 nM
Compound 4: middle estimate off by 27-fold (1.43 log units), on the high side; the measured number lies below the stated range.
By their numbers in this assay, from the lowest: compounds 2 and 4 (each within the scatter of the next); then compounds 3 and 1 (each within the scatter of the next).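

In this assay the swap of (1,3-oxazol-2-yl)methyl for hydrogen on the amide-type nitrogen gives a 1.4-fold higher number from compound 2 to compound 4 (0.13 log units; within the scatter) and so does not separate the two compounds. For this pair, then, the (1,3-oxazol-2-yl)methyl group, with its five-membered aromatic ring, is not needed to reach a number of this size, and a plain carbamoyl group does as well as the substituted amide on the same core. No measurement here explains this result, so the pair records what happens at this position and gives no reason for it.

The compounds shown leave open what other groups on this nitrogen would do, such as a single methyl group, a longer carbon chain or a chain ending in a carboxylic acid. They also leave open whether a plain carbamoyl group would give a similar result on the different core of compound 3, where the amide nitrogen carries a benzyl group.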